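The source may report more compounds than this note shows. Statements on the series, on what has been measured and on what is new or still open speak of the compounds shown alone.

Measured so far in a functional assay on the whole organism with Canis familiaris (Canis lupus familiaris) as the target, at a dose of 4 mg/kg by the oral route; a higher number here means a stronger effect of the compound at the dose given, a lower number a weaker effect:

compound 1 `Cc1nc2c(OCc3ccccc3)cccn2c1N` gives 74%
compound 2 `Cc1nc2c(OCc3cccs3)cccn2c1N` gives 80%

Compound 2 stands highest of the two numbers, with compound 1 nearest, but the step of a number 6 percentage points higher from compound 1 to compound 2 (within the scatter) lies within the scatter, so the two cannot be ranked. Compound 3 `Cc1nc2c(OCc3ccsc3)cccn2c1N` has not yet been measured. The change from compound 2 to compound 3 is thiophen-3-yl in place of thiophen-2-yl on a saturated chain carbon bound to an oxygen on an aromatic ring. Among the compounds with values here, no measured step matches this change; the only step available swaps one ring for another at the same place and stayed within the scatter, so there is no ground for expecting a move beyond the scatter here either. The expected step is a number 4 percentage points lower from compound 2 to compound 3 (within the scatter), a change not separable from the usual scatter. Compound 3 is therefore estimated at 76% in this assay, with a range from 60% to 90%.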

Compound 3, a percentage reported as inhibition, in the whole organism at one dose (the size of the read-out at that dose, not a potency): 86%
Beside the measured number, compound 3's estimate is 10 percentage points below it; the range from low to high includes it.
By their numbers in this assay, from the lowest: compounds 1, 2 and 3 (each within the scatter of the next, the first and the last beyond it).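

Changing thiophen-2-yl to thiophen-3-yl on the saturated chain carbon bound to an oxygen on an aromatic ring gives a number 6 percentage points higher from compound 2 to compound 3 (within the scatter) in this assay, so the two thiophene forms cannot be told apart at this dose. Set against phenyl at the same place, thiophen-3-yl gives a number 12 percentage points higher from compound 1 to compound 3 (beyond the scatter), a modest step and the only one here that clears the scatter, which shows that the ring at this place can change the read-out. No evidence is at hand on what lies behind these steps.

As far as these compounds go, it remains open whether a furan-3-yl or pyridin-3-yl ring at this place would match thiophen-3-yl. From the compounds shown here alone, the effect of a longer chain in place of the (thiophen-3-yl)methyl group, or of a chlorine on the thiophene ring, also remains open.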